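A Third Methoxy Group on a Styryl Lactone Core

This account rests on a few compounds, and the source may have more. Where it says the series, first, only, none or still open, it means among the compounds named here.

In a functional assay on HT-29 cells (Homo sapiens) for inhibition, read by sulforhodamine B assay, with a stated time of 48 h (a lower number here means a stronger inhibitor of growth, a higher number a weaker inhibitor of growth), compound 1 `COc1ccc(/C=C/C2CC=CC(=O)O2)cc1` gives 33.7 uM. Among the compounds with values here, compound 2 `COc1ccc(/C=C/C2CC=CC(=O)O2)c(OC)c1` gives 6.6 uM in this assay, the lowest of the two numbers measured so far, with compound 1 as its only neighbour. Within the data shown here, the one step known between them, a 5.1-fold lower number from compound 1 to compound 2 (0.71 log units; beyond the scatter), shows that adding a methoxy group to the shared core of compound 1 is worth a modest gain. Compound 3 `COc1cc(OC)c(OC)cc1/C=C/C1CC=CC(=O)O1` has not yet been measured; it differs from compound 2 by methoxy in place of hydrogen on an aromatic carbon, the new group standing ortho to a methoxy group and para to a methoxy group. Among the measured compounds shown here, only the step from compound 1 to compound 2 bears on this change, and it was modest. A further gain of similar size or smaller is therefore expected for compound 3, namely a 1.9-fold lower number from compound 2 to compound 3 (0.28 log units; within the scatter). Compound 3 is estimated at 3.5 uM, within a range of 1 uM to 12 uM.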

Compound 3, concentration for growth inhibition (reported as GI): 15.9 uM
Beside the measured number, compound 3's estimate is 4.5-fold (0.66 log units) below it, outside the stated range (above it).
By their numbers in this assay, from the lowest: compound 2; then compound 3; then compound 1.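

In this assay, the same replacement that brought a gain in a 5.1-fold lower number from compound 1 to compound 2 (0.71 log units; beyond the scatter) turns the other way at this position, giving a 2.4-fold higher number from compound 2 to compound 3 (0.38 log units; beyond the scatter), a modest step beyond the scatter. A methoxy group in place of hydrogen on an aromatic carbon therefore has no single effect in this series: where it stands ortho to a methoxy group and para to a methoxy group, it raises the number rather than lowering it. No measurement at hand accounts for this reversal.

As far as these compounds go, whether a different group would fare better at this position remains open, for example a hydroxy group, a fluorine atom or an ethoxy group. From the compounds shown here alone, it is also open whether the methoxy group would raise the number here without the two methoxy groups already on the ring.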